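The source may hold more compounds than are shown below. What is called first, only, known or untested is meant among the compounds shown, and "the series" means these compounds.

Compound 1 `C=C(Br)C(=O)Nc1cccc(/C=C2\SC(=O)N(Cc3ccc(Cl)cc3)C2=O)c1`: 2700 nM
Compound 2 `C=C(Br)C(=O)Nc1ccc(/C=C2\SC(=O)N(Cc3cccc(Cl)c3)C2=O)cc1`: 8900 nM
Compound 3 `Nc1cccc(/C=C2\SC(=O)N(Cc3cccc(F)c3)C2=O)c1`: > 250000 nM

Within the data shown here, in a functional assay on HeLa cells (Homo sapiens) for cytotoxicity, read by cell counting, with a stated time of 4 days (on this read-out higher numbers stand for weaker inhibition and lower numbers for stronger inhibition), compound 1 gives 2700 nM, the lower of the two numbers measured so far. Compound 2 gives 8900 nM, a higher number that lies beyond the usual scatter of this assay, so compound 2 is the weaker of the two; the two structures differ in more than one place, and no single change is isolated between them. Compound 3 reaches only a limit of this assay, (the limit of > 250000 nM in this assay, at which 1 of the 3 values shown sits), and no number is known for it.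

The next compound, compound 4 `C=C(Br)C(=O)Nc1cccc(/C=C2\SC(=O)N(Cc3cccc(Cl)c3)C2=O)c1`, keeps the whole of compound 1 apart from one change: 3-chlorophenyl in place of 4-chlorophenyl on a saturated chain carbon bound to an amide-type nitrogen in a ring. Among the measured compounds shown here, no pair of measured compounds differs by this change alone, so there is no measured step to lean on. With nothing pointing either way, the step from compound 1 to compound 4 is expected to be small, and the expected step of a 1.3-fold higher number from compound 1 to compound 4 (0.11 log units; within the scatter) stays within the scatter. The expected value for compound 4 in this assay is therefore 3500 nM, with a range from 1200 nM to 11000 nM.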

Compound 4, half-maximal inhibitory concentration: 2500 nM
Compound 4: the middle estimate sits 1.4-fold (0.15 log units) above what was measured; low and high end bracket the measured number.
By their numbers in this assay, from the lowest: compounds 4 and 1 (each within the scatter of the next); then compound 2. At a limit, above all of these: compound 3.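

In this assay, among these compounds, 3-chlorophenyl in place of 4-chlorophenyl on a saturated chain carbon bound to an amide-type nitrogen in a ring gives a 1.1-fold lower number from compound 1 to compound 4 (0.03 log units; within the scatter) and is the first change here that can be read alone, showing that these two chlorophenyl groups cannot be told apart at this place. Compound 4 also carries the same 3-chlorobenzyl as compound 2 and differs from it in one other place, yet compound 4 gives 2500 nM and compound 2 gives 8900 nM in this assay, so this group does not fix the number by itself. Nothing measured here gives a reason why the two groups behave alike.

The compounds shown leave open whether this holds for other groups at this place, such as a methoxy group or a carboxylic acid in place of the chlorine, or a longer chain leading to the aromatic ring. Compound 3, at > 250000 nM, stands at a limit of the assay and differs from compound 4 in more than one place, so it cannot settle this question.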